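Swapping One Ring Group on a Carbonyl Carbon

The source may report more compounds than this note shows. Statements on the series, on what has been measured and on what is new or still open speak of the compounds shown alone.

In a functional assay on A2780 cells (Homo sapiens) for antiproliferative activity, read by fluorescence, with a stated time of 72 h (on this read-out lower numbers stand for stronger inhibition and higher numbers for weaker inhibition), compound 1 `CC(=O)N1CCN(C(=O)N2Cc3c(NC(=O)c4ccc(F)cc4)n[nH]c3C2(C)C)CC1` gives > 10000 nM, which is a limit of the assay and not a number. Going by the values given here, only one other compound in this small set has a result to compare. In this assay, compound 2 `CN1CCC(C(=O)N2Cc3c(NC(=O)C4CCC4)n[nH]c3C2(C)C)CC1` gives 140 nM. Compound 3 `CC1(C)c2[nH]nc(NC(=O)c3ccc(F)cc3)c2CN1C(=O)N1CCN(c2ccccc2)CC1` adds nothing to the comparison, since its entry reads "not determined" (no result reported).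

Compound 4 `CCN1CCC(C(=O)N2Cc3c(NC(=O)c4ccc(F)cc4)n[nH]c3C2(C)C)CC1` keeps the rest of compound 1 and makes a single change: 1-ethylpiperidin-4-yl in place of 4-acetylpiperazin-1-yl on a carbonyl carbon. Put simply, 1-ethylpiperidin-4-yl stands in place of 4-acetylpiperazin-1-yl on a carbonyl carbon. The entering group has one hetero atom in its six-membered ring instead of 2, and it has no double bond outside aromatic rings.

Among the compounds with values here, no measured step isolates this change, so its size remains uncertain. Stronger inhibition is still expected in this assay because compound 2, with a similar group on its carbonyl carbon, gives 140 nM. The expected change, well beyond the usual scatter, is an at least 33-fold lower number from compound 1 to compound 4 (1.52 log units; beyond the scatter). For compound 4, the estimated half-maximal inhibitory concentration is 300 nM, with an expected range from 60 nM to 1500 nM.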

Compound 4, half-maximal inhibitory concentration: 290 nM
The estimate for compound 4 lay 1.0-fold (0.01 log units) above the measured number; low and high end bracket the measured number.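

In this assay, replacing 4-acetylpiperazin-1-yl with 1-ethylpiperidin-4-yl on a carbonyl carbon gives an at least 34-fold lower number from compound 1 to compound 4 (1.53 log units; beyond the scatter), which shows that this position alone can make a large difference to the antiproliferative read-out. The earlier compounds shown here could not show this, since compound 2 differs from compound 1 in more than one place and compound 3 has no result. The true size of the step remains unknown, and the printed figure is only a minimum, because compound 1 sits at a limit of the assay rather than at a number: the limit of > 10000 nM in this assay, at which 1 of the 4 values shown sits.

Several things change together in this single swap, including the number of hetero atoms in the ring, the loss of the double bond outside aromatic rings and the total number of heavy atoms, so the compounds shown do not reveal which of these matters. A cyclohexyl ring with no nitrogen, or a piperidin-4-yl ring carrying a longer chain such as propyl on its nitrogen, on the same carbonyl carbon of compound 4 would help to separate the role of the ring nitrogen from that of its ethyl group.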